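Thioether chain replacement in a pyridine series

The source may hold more compounds than are shown below. What is called first, only, known or untested is meant among the compounds shown, and "the series" means these compounds.

Compounds with values in an assay on CHO-K1 cells for antagonist activity at transient receptor potential cation channel subfamily V member 1 (Homo sapiens), read by FLIPR; on this read-out lower numbers stand for stronger inhibition and higher numbers for weaker inhibition:
- compound 1, `CC(C(=O)NCc1ccc(C(F)(F)F)nc1SCCOc1ccccc1)c1ccc(NS(C)(=O)=O)c(F)c1`: 2.3 nM
- compound 2, `CC1CCN(CCCSc2nc(C(F)(F)F)ccc2CNC(=O)C(C)c2ccc(NS(C)(=O)=O)c(F)c2)CC1`: 2.9 nM
- compound 3, `CC(C(=O)NCc1ccc(C(F)(F)F)nc1SCCC(=O)O)c1ccc(NS(C)(=O)=O)c(F)c1`: "not active" (no number reported)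
- compound 4, `CC(C(=O)NCc1ccc(C(F)(F)F)nc1[S+]([O-])C1CCCCC1)c1ccc(NS(C)(=O)=O)c(F)c1`: not yet measured

Compound 3 stands apart from the others: in this assay compound 1 gives 2.3 nM and compound 2 gives 2.9 nM, while compound 3 returned "not active" (no number reported) and no measurable number at all. Among the compounds with values here, the only step between measured compounds, a 1.3-fold higher number from compound 1 to compound 2 (0.10 log units; within the scatter), shows that exchanging one neutral chain end for another on the sulfur-bound chain leaves the number essentially unchanged. The change from compound 3 to compound 4 is of a different kind: a group of 8 heavy atoms (6 carbon, 1 oxygen, 1 sulfur; one six-membered non-aromatic ring of carbon only) in place of a group of 6 heavy atoms (3 carbon, 2 oxygen, 1 sulfur; no ring), on an aromatic carbon. Within the data shown here, no measured pair mirrors this change, so the size of the step cannot be read from the series; the (2-carboxyethyl)sulfanyl group is the one feature that separates the inactive compound 3 from compounds 1 and 2, and its removal is the main ground for expecting a measurable number. For compound 4 the estimate is 25 nM, with a range from 3 nM to 250 nM.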

Compound 4, inhibition constant: "not active" (no number reported)
The entry for compound 4 holds no number; the estimate stays without a comparison.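

In this assay, within the data shown here, compound 3 and compound 4 both returned no number, and no step between them can be read. No measured property bears on this result. The compounds shown leave open which feature of the sulfur-bound group separates compound 3 and compound 4 from compound 1 and compound 2.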